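A few compounds are considered here, and "the series" means these few. Any claim that something is new, unique, unknown or untested is made for them only; others in the source may bear on it.

The measured compounds are compound 1 `CCN1CCN(c2cc(C)c3cc(NC(=O)c4ccc(Cl)cc4)ccc3n2)CC1`, compound 2 `CCN1CCN(c2cc(C)c3cc(NC(=O)c4ccc(F)cc4)ccc3n2)CC1` and compound 3 `CCN1CCN(c2cc(C)c3cc(NC(=O)c4ccc(Cl)c(Cl)c4)ccc3n2)CC1`. In a functional assay on MCF7 cells (Homo sapiens) for antiproliferative activity, read by MTT assay, with a stated time of 72 h (a higher number here means a weaker inhibitor, a lower number a stronger inhibitor), compound 1 gives 1530 nM, compound 2 gives 4030 nM and compound 3 gives 1380 nM.

Compound 3 carries the lowest of the three numbers, yet its separation from compound 1 is within the scatter: a 1.1-fold lower number from compound 1 to compound 3 (0.04 log units; within the scatter). Only against compound 2 does it stand apart, a 2.9-fold lower number from compound 2 to compound 3 (0.47 log units; beyond the scatter), which is a modest step. Compound 4 `CCN1CCN(c2cc(C)c3cc(NC(=O)c4ccccc4Br)ccc3n2)CC1` has not yet been measured in this assay. Compared with compound 3 the change is 2-bromophenyl in place of 3,4-dichlorophenyl on a carbonyl carbon.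

For the measured compounds named here, two measured steps bear on the ring on the carbonyl carbon. Exchanging fluoro for chloro gave a 2.6-fold higher number from compound 1 to compound 2 (0.42 log units; beyond the scatter), a modest change, while adding a second chloro gave a 1.1-fold lower number from compound 1 to compound 3 (0.04 log units; within the scatter), which is within the scatter. Neither step changes a halogen at the position now occupied by the bromine, and none places a single halogen there, so the measured steps reach compound 4 only loosely. Because a 1.1-fold lower number from compound 1 to compound 3 (0.04 log units; within the scatter) is within the scatter and a 2.6-fold higher number from compound 1 to compound 2 (0.42 log units; beyond the scatter) only modest, a small shift toward a higher number or none beyond the scatter is expected, a 1.5-fold higher number from compound 3 to compound 4 (0.18 log units; within the scatter). Compound 4 is therefore estimated at 2100 nM in this assay, within a range from 800 nM to 6000 nM.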

Compound 4, half-maximal inhibitory concentration: 27500 nM
Compound 4: middle estimate off by 13-fold (1.12 log units), on the low side, and the stated range ends below it.
By their numbers in this assay, from the lowest: compounds 3 and 1 (each within the scatter of the next); then compound 2; then compound 4.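

In this assay, 2-bromophenyl on the carbonyl carbon gives a 20-fold higher number from compound 3 to compound 4 (1.30 log units; beyond the scatter), and the steps from the two singly halogenated compounds point the same way: an 18-fold higher number from compound 1 to compound 4 (1.25 log units; beyond the scatter) and a 6.8-fold higher number from compound 2 to compound 4 (0.83 log units; beyond the scatter). The earlier compounds shown here, with 4-chlorophenyl, 4-fluorophenyl and 3,4-dichlorophenyl at this place, showed only steps within the scatter or modest ones, whereas compound 4 shows that a change on this ring can move the number much further, and it stands apart from all three. Nothing given here explains this rise.

The compounds shown leave open whether the bromine itself or its place on the ring goes with the higher number, since the step from 4-chlorophenyl to 2-bromophenyl changes both at once. A 2-chlorophenyl or a 4-bromophenyl group on the same carbonyl carbon would separate the two, and an unsubstituted phenyl group would show how the ring behaves with no halogen at all.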